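Methyl addition on the anilino ring, second core

The compounds below may be only part of what the source reports. "The series", "measured", "known", "first", "only" and "open" are said of these compounds alone.

Measured so far:
compound 1 `COc1cc(OC)c2sc(-c3ccc(N/C=C\C(=O)c4ccc(OC)c([N+](=O)[O-])c4)c(C)c3)nc2c1` gives 12100 nM
compound 2 `COc1cc(OC)c2sc(-c3ccc(N/C=C\C(=O)c4ccc(OC)c([N+](=O)[O-])c4)cc3)nc2c1` gives 5800 nM
compound 3 `COc1ccc2nc(-c3ccc(N/C=C\C(=O)c4ccc(OC)c([N+](=O)[O-])c4)cc3)sc2c1` gives 13600 nM

In a functional assay on A549 cells (Homo sapiens) for antiproliferative activity, read by sulforhodamine B assay, with a stated time of 48 h (a lower number here means a stronger inhibitor, a higher number a weaker inhibitor), compound 2 gives 5800 nM, and compound 1 gives 12100 nM. The change between them, (methyl in place of hydrogen on an aromatic carbon), made a 2.1-fold higher number from compound 2 to compound 1 (0.32 log units; beyond the scatter). Compound 3 carries a different core; the difference between the two cores is not broken down here. In this assay compound 3 gives 13600 nM.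

Compound 4 `COc1ccc2nc(-c3ccc(N/C=C\C(=O)c4ccc(OC)c([N+](=O)[O-])c4)c(C)c3)sc2c1` is not yet measured. It differs from compound 3 by methyl in place of hydrogen on an aromatic carbon, the same kind of change as that from compound 2 to compound 1; the place is meta to a 6-methoxy-1,3-benzothiazol-2-yl group here rather than meta to a large group. For compound 4 the expected step is a 2.1-fold higher number from compound 3 to compound 4 (0.31 log units; beyond the scatter), resting on compound 2 to compound 1 showing a 2.1-fold higher number from compound 2 to compound 1 (0.32 log units; beyond the scatter). Compound 4 is therefore estimated at 28000 nM, expected within 12000 nM to 60000 nM.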

Compound 4, half-maximal inhibitory concentration: 13600 nM
Compound 4: the middle estimate sits 2.1-fold (0.31 log units) above what was measured; the measured number falls inside the stated range.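

In this assay, methyl in place of hydrogen on the aromatic carbon gives no change at the digits printed from compound 3 to compound 4 (within the scatter). Set beside the step on the other core, the two results cannot be told apart: the same change on two cores in this assay, a 2.1-fold higher number (0.32 log units; beyond the scatter) from compound 2 to compound 1 and no change at the digits printed (within the scatter) from compound 3 to compound 4, 2.1-fold (0.32 log units) apart, within the scatter of two such steps The change therefore cannot be said to depend on the core, yet a firm carry-over of the earlier step is not shown either, and one pair per core gives no basis for a general rule or an explanation.

Still open, from the compounds shown here alone, is whether an ethyl group or a chlorine atom at the same place would behave as methyl does on either core. Also open, going by these compounds, is whether the step would hold if an amine stood in place of the nitro group.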